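Aryl ester series: the step to compound 4

The compounds below may be only part of what the source reports. "The series", "measured", "known", "first", "only" and "open" are said of these compounds alone.

Values in a toxicity assay on cells (Fibroblast, Homo sapiens) for cytotoxicity; on this read-out lower numbers stand for stronger inhibition and higher numbers for weaker inhibition:
- compound 1 `CC(/C=C/C1=CCCCC1(C)C)=C\C=C\C(C)=C\COC(=O)c1cc(O)ccc1O` gives 14000 nM
- compound 2 `CC(/C=C/C1=CCCCC1(C)C)=C\C=C\C(C)=C\COC(=O)c1ccccc1O` gives 150000 nM
- compound 3 `COc1cc(O)c(C(=O)OC/C=C(C)/C=C/C=C(C)/C=C/C2=CCCCC2(C)C)c(O)c1` gives 14000 nM

Compound 3 stands level with compound 1, the two together holding the lowest of the three numbers. Next comes compound 4 `COc1cccc(O)c1C(=O)OC/C=C(C)/C=C/C=C(C)/C=C/C1=CCCCC1(C)C`, with the change (a group of 9 heavy atoms (7 carbon, 2 oxygen; one six-membered aromatic ring of carbon only) in place of a group of 10 heavy atoms (7 carbon, 3 oxygen; one six-membered aromatic ring of carbon only), on a carbonyl carbon), so that 2-hydroxy-6-methoxyphenyl sits on the carbonyl carbon. The nearest measured precedent, hydrogen in place of hydroxy, is an 11-fold higher number from compound 1 to compound 2 (1.03 log units; beyond the scatter). The reverse direction appears in an 11-fold lower number from compound 2 to compound 3 (1.03 log units; beyond the scatter), whereas no change at the digits printed from compound 1 to compound 3 (within the scatter) shows no shift. Compound 4 keeps a methoxy that compound 2 at 150000 nM lacks, so a higher number is expected in this assay, but short of that large step. The expected step is a 3.2-fold higher number from compound 3 to compound 4 (0.51 log units; beyond the scatter). Compound 4 is estimated at 45000 nM, within an expected range of 15000 nM to 130000 nM.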

Compound 4, half-maximal inhibitory concentration: 230000 nM
The estimate for compound 4 lay 5.1-fold (0.71 log units) below the measured number; the whole stated range lies below it.
By their numbers in this assay, from the lowest: compounds 1 and 3 (each within the scatter of the next); then compounds 2 and 4 (each within the scatter of the next).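

In this assay, 2-hydroxy-6-methoxyphenyl on the carbonyl carbon does not keep the low number of the dihydroxy esters, with a 16-fold higher number from compound 3 to compound 4 (1.22 log units; beyond the scatter) and a 16-fold higher number from compound 1 to compound 4 (1.22 log units; beyond the scatter) as the large steps. Methoxy in place of hydrogen on an aromatic carbon gives a 1.5-fold higher number from compound 2 to compound 4 (0.19 log units; within the scatter), so across these four compounds the low numbers stay with the dihydroxy groups of compound 1 and compound 3, and methoxy alone does not bring them. Nothing available explains this shift.

Still open, on these data alone, is whether 2,6-dihydroxyphenyl without any methoxy would sit with compound 3. Also open, as far as these compounds go, is how an aromatic amine or a carboxylic acid in place of the hydroxy would read.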